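Anilinoquinazoline acrylamides: nitro for methyl at the anilino ring

The compounds below may be only part of what the source reports. "The series", "measured", "known", "first", "only" and "open" are said of these compounds alone.

Among the measured compounds shown here, compound 2 `C=CC(=O)Nc1cccc(NC(=O)CSc2nc(Nc3ccccc3C)c3ccccc3n2)c1` gives 23200 nM in a functional assay on PC-3 cells (Homo sapiens) for inhibition, read by MTT assay, with a stated time of 72 h (on this read-out lower numbers stand for stronger inhibition and higher numbers for weaker inhibition), which is the higher of the two numbers measured so far. Its nearest neighbour is compound 1 `C=CC(=O)Nc1cccc(NC(=O)CSc2nc(Nc3ccccc3)c3ccccc3n2)c1`, which in this assay gives 8740 nM; the step of a 2.7-fold higher number from compound 1 to compound 2 (0.42 log units; beyond the scatter) is the only one yet measured and it concerns the same ring, a methyl replacing hydrogen.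

Compound 3 `C=CC(=O)Nc1cccc(NC(=O)CSc2nc(Nc3cccc([N+](=O)[O-])c3)c3ccccc3n2)c1` has not been measured. The change from compound 2 is 3-nitrophenyl in place of 2-methylphenyl on a nitrogen on an aromatic ring. For the measured compounds named here, no measured step bears directly on a nitro group on this ring; the one available step, a 2.7-fold higher number from compound 1 to compound 2 (0.42 log units; beyond the scatter), shows that substitution on the anilino ring shifts the number to a modest degree, and compound 3 is expected to land somewhere in that neighbourhood. A return to a value closer to compound 1, that is a modestly lower number than compound 2, is expected, because the methyl that raised the number in a 2.7-fold higher number from compound 1 to compound 2 (0.42 log units; beyond the scatter) is removed. For compound 3 the estimate in this assay is 12000 nM, within 4000 nM to 36000 nM, which is the expected step of a 1.9-fold lower number from compound 2 to compound 3 (0.29 log units; within the scatter).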

Compound 3, half-maximal inhibitory concentration: 46300 nM
For compound 3 the middle estimate is 3.9-fold (0.59 log units) below the measured one, and the stated range ends below it.
By their numbers in this assay, from the lowest: compound 1; then compounds 2 and 3 (each within the scatter of the next).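

Notes on the anilino ring: in this assay, the nitro group gives a 5.3-fold higher number from compound 1 to compound 3 (0.72 log units; beyond the scatter), so a second substituent, different from the methyl, also separates from the unsubstituted ring of compound 1 by more than the scatter. For the two substituted compounds the step is a 2.0-fold higher number from compound 2 to compound 3 (0.30 log units; within the scatter), so 3-nitrophenyl and 2-methylphenyl cannot be told apart here, although the group and its place on the ring both differ. Among the three compounds, both substituted rings give higher numbers than the unsubstituted ring, with no compound going against this, but nothing available explains the pattern.

In the compounds shown, the identity of the group and its place on the ring change together, so their separate contributions remain unresolved. From the compounds shown here alone, it also remains open whether an amine, a methoxy group or a carboxylic acid on this ring would likewise give a higher number than compound 1 at 8740 nM, or whether any group on this ring could give a lower one.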